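A few compounds are considered here, and "the series" means these few. Any claim that something is new, unique, unknown or untested is made for them only; others in the source may bear on it.

Measured in an ADME assay on MCF-10A cells (Homo sapiens) for cytotoxicity, read by MTT assay, with a stated time of 96 h; on this read-out lower numbers stand for stronger inhibition and higher numbers for weaker inhibition:
- compound 1 `COc1ccc(-c2cc(-c3ccc(OC)c(OC)c3)cc(=O)[nH]2)c(OC)c1`: 50000 nM
- compound 2 `COc1ccc(-c2cc(-c3ccc4c(c3)OCCO4)cc(=O)[nH]2)c(OC)c1`: 6000 nM

Compound 1 has the higher of these two numbers, and the gap down to compound 2 lies beyond the usual scatter. Compound 1 is therefore the weaker inhibitor of the pair in this assay.

Compound 3 `COc1ccc(-c2cc(-c3ccc(OC)cc3OC)[nH]c(=O)c2)cc1` has not yet been measured. It arises from compound 1 through a single change: hydrogen in place of methoxy on an aromatic carbon. In words, hydrogen stands in place of methoxy on an aromatic carbon.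

Among the compounds with values here, no measured pair shows this change, so the expectation is loose. Within the data shown here, compound 1, at 50000 nM, sits at the top of the values so far, so a moderate fall in the number is expected rather than a rise. The expected move is a 3.3-fold lower number from compound 1 to compound 3 (0.52 log units; beyond the scatter). For compound 3 the estimated value is 15000 nM, with an expected range from 3000 nM to 60000 nM.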

Compound 3, half-maximal inhibitory concentration: 1600 nM
Compound 3: the middle estimate sits 9.4-fold (0.97 log units) above what was measured; the whole stated range lies above it.
By their numbers in this assay, from the lowest: compound 3; then compound 2; then compound 1.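

In this assay, hydrogen in place of methoxy on this aromatic carbon, ortho to a methoxy group, gives a 31-fold lower number from compound 1 to compound 3 (1.49 log units; beyond the scatter) and so makes a large step, well beyond the usual scatter. The earlier compounds shown here said nothing about this carbon taken alone, whereas this step shows that the number depends strongly on what sits there. A methoxy group at this place goes with the much higher number, and a plain hydrogen with the much lower one. Nothing available explains why the number falls so far.

From the compounds shown here alone, it remains open whether a fluorine atom, a hydroxyl group or an amine at this carbon would give a number nearer that of compound 1 or that of compound 3. Going by these compounds, it is also open whether removing either of the other methoxy groups would bring a step of similar size.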